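Deacetylation of a chromone: from compound 3 to compound 4

The source may hold more compounds than are shown below. What is called first, only, known or untested is meant among the compounds shown, and "the series" means these compounds.

The measured compounds:
compound 1 `CC(=O)Oc1cc(OC(C)=O)c2c(=O)cc(-c3ccccc3)oc2c1`, 4500 nM
compound 2 `CC(=O)Oc1cc(O)c2c(=O)cc(-c3ccccc3)oc2c1`, 3600 nM
compound 3 `CC(=O)Oc1c(I)c(O)c2c(=O)cc(-c3ccccc3)oc2c1I`, 4200 nM

All three were tested in a functional assay on SGC-7901 cells (Homo sapiens) for inhibition; a higher number here means a weaker inhibitor, a lower number a stronger inhibitor. Compound 1 and compound 2 differ by hydrogen in place of acetyl on an oxygen on an aromatic ring. That change gave a 1.3-fold lower number from compound 1 to compound 2 (0.10 log units; within the scatter), so the two values sit within the scatter of each other and no order can be read from them. Compound 3 carries two iodine atoms in place of two ring hydrogens of compound 1; how the two cores differ is not broken down here, but the numbers of compound 1 and compound 3 lie close together, and compound 3 is also close to compound 2.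

Compound 4 `O=c1cc(-c2ccccc2)oc2c(I)c(O)c(I)c(O)c12` has not yet been measured. It differs from compound 3 by hydrogen in place of acetyl on an oxygen on an aromatic ring, the same change as that from compound 1 to compound 2, at a place described in the same words. The earlier step barely moved the number. A step of similar size is therefore expected, a 1.2-fold lower number from compound 3 to compound 4 (0.08 log units; within the scatter), because compound 3 starts at 4200 nM and the matching step gave a 1.3-fold lower number from compound 1 to compound 2 (0.10 log units; within the scatter). Compound 4 is thus estimated at 3500 nM, with a range from 1800 nM to 7000 nM.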

Compound 4, half-maximal inhibitory concentration: 2900 nM
Estimate against measurement, compound 4: 1.2-fold (0.08 log units) above; low and high end bracket the measured number.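

Going from acetoxy to hydroxy on the core that carries two iodine atoms gave, in this assay, a 1.4-fold lower number from compound 3 to compound 4 (0.16 log units; within the scatter), so that pair cannot be put in order. Set beside the earlier step, the same change shows no detectable difference in size between the two cores: the same change on two cores in this assay, a 1.3-fold lower number (0.10 log units; within the scatter) from compound 1 to compound 2 and a 1.4-fold lower number (0.16 log units; within the scatter) from compound 3 to compound 4, 1.2-fold (0.06 log units) apart, within the scatter of two such steps. Within the data shown here, on both cores the change stays within the scatter, so the result carries over in the sense that neither pair can be separated, but this rests on only two pairs, says nothing about any other core, and cannot show how the change would transfer where it moved the number clearly.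

The compounds shown leave open whether a different group on that oxygen, such as a methyl ether or a longer acyl chain, would shift the number beyond the scatter. They also leave open what an amine or a carboxylic acid would do elsewhere on the shared core.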